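Pyridazin-3-yl for Furan-2-yl on the Amide Carbonyl

The compounds below may be only part of what the source reports. "The series", "measured", "known", "first", "only" and "open" are said of these compounds alone.

Compound 1 `O=C(Nc1ccc(F)cc1CN1C(=O)c2ccccc2C1=O)c1ccccn1` gives 1500 nM in an assay on CHO cells for positive allosteric modulation of metabotropic glutamate receptor 5 (Homo sapiens), read by FLIPR; on this read-out lower numbers stand for an effect already at smaller amounts and higher numbers for an effect only at larger amounts of compound.
Compound 2 `O=C(Nc1ccc(Cl)cc1CN1C(=O)c2ccccc2C1=O)c1ccco1` gives 2300 nM in this assay.
Compound 3 `O=C(Nc1ccc(Cl)cc1CN1C(=O)c2ccc(F)cc2C1=O)c1ccccn1` gives 330 nM in this assay.

Compound 2 carries the highest number of the three. Compound 1 lies within the scatter of it, so no order between these two can be stated, whereas compound 3 stands beyond the scatter at a clearly lower number. Compound 4 `O=C(Nc1ccc(Cl)cc1CN1C(=O)c2ccccc2C1=O)c1cccnn1` differs from compound 2 in one place: pyridazin-3-yl in place of furan-2-yl on a carbonyl carbon. Within the data shown here, no measured pair shows this change, so its step has to be estimated. A modest move toward lower numbers, close to the edge of the scatter, is expected, and the estimate means a step of a 1.9-fold lower number from compound 2 to compound 4 (0.28 log units; within the scatter). In this assay compound 4 is expected to give 1200 nM, within a range from 400 nM to 3500 nM.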

Compound 4, half-maximal effective concentration: > 100000 nM
Compound 4 ended at the assay's limit; the forecaster's own chance of this, stated with the estimate: 5%; middle value at least 83-fold (1.92 log units) from the limit.
By their numbers in this assay, from the lowest: compound 3; then compounds 1 and 2 (each within the scatter of the next). At a limit, above all of these: compound 4.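

Compound 4 sits at a limit of this assay: the limit of > 100000 nM in this assay, at which 1 of the 4 values shown sits. The earlier compounds shown here offered no pair differing in one place, whereas pyridazin-3-yl in place of furan-2-yl on the carbonyl carbon now gives an at least 43-fold higher number from compound 2 to compound 4 (1.63 log units; beyond the scatter). On the core of compound 2, this position therefore does not treat these two aromatic rings alike.

The compounds shown do not separate the six-membered ring from the added ring nitrogen as the source of this step. From the compounds shown here alone, how phenyl or thiophen-2-yl would read on the same carbonyl carbon remains open.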